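This account rests on a few compounds, and the source may have more. Where it says the series, first, only, none or still open, it means among the compounds named here.

Series notes. Compound 1 `Cc1c(C(=O)N[C@@H](C)c2ccc(C(=O)O)cc2)nnn1Cc1ccc(C(F)(F)F)cc1`, compound 2 `CCc1c(C(=O)N[C@@H](C)c2ccc(C(=O)O)cc2)nnn1Cc1ccc(C(F)(F)F)cc1` and compound 3 `CCCc1c(C(=O)N[C@@H](C)c2ccc(C(=O)O)cc2)nnn1Cc1ccc(C(F)(F)F)cc1` share one core and differ only in the alkyl on the five-membered ring. In a functional assay on CHO cells for antagonist activity at prostaglandin E2 receptor EP4 subtype (Homo sapiens), read by calcium flux, with a stated time of 15 min (a lower number here means a stronger inhibitor, a higher number a weaker inhibitor), compound 1 gives > 10000 nM, which is a limit of the assay and not a number. Compound 2 gives > 10000 nM, likewise a limit. Compound 3 gives > 10000 nM, again a limit, so on the numbers shown compound 3 stands at the limit with both others. Because every value sits at the limit of > 10000 nM in this assay, at which 3 of the 3 values shown sit, the steps a step that the two limits leave unreadable from compound 1 to compound 2, a step that the two limits leave unreadable from compound 1 to compound 3 and a step that the two limits leave unreadable from compound 2 to compound 3 are unreadable. Compound 4 `C[C@H](NC(=O)c1nnn(Cc2ccc(C(F)(F)F)cc2)c1-c1ccccc1)c1ccc(C(=O)O)cc1` carries the change (phenyl in place of propyl on an aromatic carbon). Among the measured compounds shown here, no measured step bears on it, and the step that the limit leaves unreadable from compound 3 to compound 4 is an expectation only, with a high chance of a further limit. Compound 4 is expected to give 12000 nM, within 3000 nM to 50000 nM.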

Compound 4, half-maximal inhibitory concentration: > 10000 nM
Compound 4: only a limit was reported; the forecaster's own chance of this, stated with the estimate: 60%; the middle value lies beyond the limit too.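

Compound 4 gives > 10000 nM in this assay, again a limit and not a number. No step among compound 1, compound 2, compound 3 and compound 4 can be read: the limit of > 10000 nM in this assay, at which 4 of the 4 values shown sit.

The compounds shown leave open whether any group at this place on the five-membered ring would give a value inside the range of this assay.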